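The source may report more compounds than this note shows. Statements on the series, on what has been measured and on what is new or still open speak of the compounds shown alone.

Measured compounds:
compound 1 `COc1ccc(-c2ncnn2-c2cc(OC)c(OC)c(OC)c2)cc1` – 520 nM
compound 2 `COc1cc(-c2ncnn2-c2ccc(F)cc2)cc(OC)c1OC` – > 10000 nM
compound 3 `COc1cc(-c2ncnn2-c2ccc(Cl)c(Cl)c2)cc(OC)c1OC` – > 10000 nM

Within the data shown here, in a functional assay on A549 cells (Homo sapiens) for antiproliferative activity, read by MTT assay, with a stated time of 72 h (a lower number here means a stronger inhibitor, a higher number a weaker inhibitor), compound 1 gives 520 nM, the only plain number among the three. Compound 2 reaches only a limit of the assay, > 10000 nM. Compound 3 likewise reaches only a limit, > 10000 nM. The step that the two limits leave unreadable from compound 2 to compound 3 therefore cannot be sized, because both ends sit at the limit of > 10000 nM in this assay, at which 2 of the 3 values shown sit.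

Compound 4 `COc1cc(-n2ncnc2-c2ccc(SC)cc2)cc(OC)c1OC` differs from compound 1 in one place: methylsulfanyl in place of methoxy on an aromatic carbon, read one bond further out as 4-methoxyphenyl to 4-(methylsulfanyl)phenyl. Among the measured compounds shown here, none of the measured steps touches this group, so nothing here argues for a change beyond the usual scatter. The step expected is a 1.2-fold higher number from compound 1 to compound 4 (0.06 log units; within the scatter), within that scatter. Compound 4 is estimated at 600 nM, in a range from 150 nM to 2500 nM.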

Compound 4, half-maximal inhibitory concentration: 800 nM
Beside the measured number, compound 4's estimate is 1.3-fold (0.12 log units) below it; the measured number falls inside the stated range.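

In this assay, methylsulfanyl in place of methoxy gives a 1.5-fold higher number from compound 1 to compound 4 (0.19 log units; within the scatter), so compound 1 and compound 4 cannot be told apart. This is the first step among the compounds shown whose size can be read, and it shows that this position tolerates sulfur in place of oxygen in this one group. Whether the same position also accepts an amine, a carboxylic acid or a longer chain such as butoxy remains open, and nothing shown gives a cause for this result.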